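Cytotoxicity notes: the nitro analogue of compound 3

The source may hold more compounds than are shown below. What is called first, only, known or untested is meant among the compounds shown, and "the series" means these compounds.

The series shares one core: compound 1 is `C=Cc1cccc(C(=O)N2CCCC(C(=O)Nc3ccc(Cl)cc3)C2)c1`, compound 2 is `COc1cccc(C(=O)N2CCCC(C(=O)Nc3ccc(Cl)cc3)C2)c1` and compound 3 is `CS(=O)(=O)Nc1cccc(C(=O)N2CCCC(C(=O)Nc3ccc(Cl)cc3)C2)c1`. In an ADME assay on PC-3 cells (Homo sapiens) for cytotoxicity, read by WST assay, tested at 100 uM (a higher number here means more inhibition at the concentration tested (going by the name of the read-out), a lower number less inhibition), compound 1 gives 0%, compound 2 gives 0% and compound 3 gives 3%. Compound 3 holds the highest of the three numbers, but a number 3 percentage points higher from compound 1 to compound 3 (within the scatter) and a number 3 percentage points higher from compound 2 to compound 3 (within the scatter) lie within the scatter, as does no change at the digits printed from compound 1 to compound 2 (within the scatter), so the three compounds are indistinguishable in this assay.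

Compound 4 is `O=C(Nc1ccc(Cl)cc1)C1CCCN(C(=O)c2cccc([N+](=O)[O-])c2)C1` and is not yet measured. Its change from compound 3 is this: nitro in place of methanesulfonamido on an aromatic carbon. Among the measured compounds shown here, no measured step introduces a nitro group; the steps that bear on it are those that vary the same aromatic carbon, vinyl to methoxy, vinyl to methanesulfonamido and methoxy to methanesulfonamido, none of which moved the number beyond the scatter. A step of no change at the digits printed from compound 3 to compound 4 (within the scatter) is therefore expected, meaning none beyond the scatter. Compound 4 is estimated at 3% in this assay, expected to fall between 0% and 12%.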

Compound 4, a percentage reported as inhibition, at one concentration (the size of the read-out at that concentration, not a potency): 0%
Compound 4: the middle estimate sits 3 percentage points above what was measured; the measured number falls inside the stated range.
By their numbers in this assay, from the lowest: compounds 1, 2, 4 and 3 (each within the scatter of the next).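

In this assay, nitro adds a fourth group at this aromatic carbon, meta to a large group, and it does not separate from the other three: the read-out gives a number 3 percentage points lower from compound 3 to compound 4 (within the scatter), no change at the digits printed from compound 2 to compound 4 (within the scatter) and no change at the digits printed from compound 1 to compound 4 (within the scatter). The change from methanesulfonamido to nitro gives up the sulfur and the hydrogen-bond donor, yet no step beyond the scatter comes with it, so the number stays flat across all four groups at this position. Nothing at hand bears on why the number stays flat here.

Going by these compounds, whether any group on this carbon can move the number beyond the scatter stays open; an amine, a carboxylic acid or a longer chain would test that. On these data alone, all four compounds keep the rest of the shared core unchanged, so the effect of a change elsewhere also stays open.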